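A few compounds are considered here, and "the series" means these few. Any claim that something is new, unique, unknown or untested is made for them only; others in the source may bear on it.

Measured in a physicochemical assay for solubility, in phosphate buffer, at pH 7.4; a higher number here means a more soluble compound, a lower number a less soluble compound:

- Compound 1 `CCOC(=O)c1c(-c2ccc(OC)cc2)[nH]c2cccc(OC)c2c1=O` gives > 100000 nM, a limit.
- Compound 2 `CCOC(=O)c1c(-c2cccc(OC)c2)[nH]c2cccc(OC)c2c1=O` gives > 100000 nM, a limit.
- Compound 3 `CCOC(=O)c1c(-c2ccc(Cl)c(Cl)c2)[nH]c2cccc(OC)c2c1=O` gives 39000 nM.

Compound 3 alone carries a number, while the other two stand at the limit of > 100000 nM in this assay, at which 2 of the 3 values shown sit. The change under consideration leads to compound 4 `CCOC(=O)c1c(-c2cccc(C)c2)[nH]c2cccc(OC)c2c1=O`: 3-methylphenyl in place of 3,4-dichlorophenyl on an aromatic carbon. It puts 3-methylphenyl in place of 3,4-dichlorophenyl on an aromatic carbon, next to the ring nitrogen and ortho to an ethoxycarbonyl group.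

For the measured compounds named here, two measured steps bear on this change: an at least 2.5-fold lower number from compound 1 to compound 3 (0.40 log units; beyond the scatter) and an at least 2.5-fold lower number from compound 2 to compound 3 (0.40 log units; beyond the scatter). As far as these compounds go, both end at the 3,4-dichlorophenyl group and both lie beyond the scatter, but each starts from a limit, so its full size stays open. The remaining step, a step that the two limits leave unreadable from compound 1 to compound 2, cannot be read and adds nothing here.

Compound 4 gives up the 3,4-dichlorophenyl group, so it is expected to reverse part of an at least 2.5-fold lower number from compound 2 to compound 3 (0.40 log units; beyond the scatter). Going by the values given here, no measured compound carries 3-methylphenyl, so the size remains uncertain. The expected change is modest and towards a higher number, and a result at the limit would be no surprise: a 1.8-fold higher number from compound 3 to compound 4 (0.25 log units; within the scatter). For compound 4 the estimate is 70000 nM, with an expected range of 35000 nM to 100000 nM.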

Compound 4, solubility: > 100000 nM
Compound 4: a limit, no number (the forecaster's own chance of this, stated with the estimate: 35%); middle value at least 1.4-fold (0.15 log units) away from the limit.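

In this assay the change to 3-methylphenyl gives an at least 2.5-fold higher number from compound 3 to compound 4 (0.40 log units; beyond the scatter), so at this aromatic carbon, next to the ring nitrogen and ortho to an ethoxycarbonyl group, the lower number does not carry over from 3,4-dichlorophenyl to a 3-methylphenyl group. The earlier compounds shown here left open whether the lower number of compound 3 simply followed the loss of a methoxy group from the phenyl ring; compound 4 also has no methoxy group, yet does not share that number, which points to the 3,4-dichlorophenyl group itself within this small set. Compound 4 gives > 100000 nM, a limit, so the full size of its step from compound 3 stays open and the steps between it and the two methoxyphenyl compounds cannot be read: the limit of > 100000 nM in this assay, at which 3 of the 4 values shown sit.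

The compounds shown do not separate the two chlorines, so it remains open whether a phenyl group with one chlorine would stay at the limit or give a readable number. As far as these compounds go, how an aminomethyl group or a carboxylic acid on this phenyl ring would read in this assay is also open.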